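The source may report more compounds than this note shows. Statements on the series, on what has been measured and on what is new or still open speak of the compounds shown alone.

Working notes on the sulfonyl series. Compound 1 `COc1ccc(-c2cc(=O)c3c(OC)cc(OC)cc3n2S(=O)(=O)c2ccc([N+](=O)[O-])cc2)cc1` in a functional assay on KOPN-8 cells (Homo sapiens) for antiproliferative activity, with a stated time of 72 h (on this read-out higher numbers stand for an effect only at larger amounts of compound and lower numbers for an effect already at smaller amounts), gives 17300 nM. Compound 2 `COc1ccc(-c2cc(=O)c3c(OC)cc(OC)cc3n2S(=O)(=O)c2ccc(C#N)cc2)cc1` in this assay reaches only a limit, > 17200 nM. Compound 3 `COc1ccc(-c2cc(=O)c3c(OC)cc(OC)cc3n2S(=O)(=O)c2cc(Cl)cc(Cl)c2O)cc1` in this assay also reaches only a limit, > 37900 nM. Compound 3 therefore stands at the limit of > 37900 nM in this assay, at which 1 of the 3 values shown sits, the higher of the two limits in the set, with no number of its own. The steps that lead into it read an at least 2.1-fold higher number from compound 1 to compound 3 (0.34 log units; beyond the scatter) and a step that the two limits leave unreadable from compound 2 to compound 3; the remaining pair gives a step that the limit leaves unreadable from compound 1 to compound 2. Every change on the sulfonyl substituent so far ends at or near a limit, and no readable direction emerges from three points.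

Compound 4 `COc1ccc(-c2cc(=O)c3c(OC)cc(OC)cc3n2S(=O)(=O)c2ccc(Br)s2)cc1` differs from compound 3 by 5-bromothiophen-2-yl in place of 3,5-dichloro-2-hydroxyphenyl on a sulfonyl sulfur. The measured steps offer no readable size for this kind of exchange, so no step beyond the scatter is expected in this assay, with a fair chance that only a limit is reported again. For compound 4 the expected value in this assay is 20000 nM, with a range from 5000 nM to 60000 nM. The implied step an at least 1.8-fold lower number from compound 3 to compound 4 (0.27 log units; that floor lies within the scatter) is an estimate only.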

Compound 4, half-maximal effective concentration: > 48200 nM
Compound 4: a limit, no number (the forecaster's own chance of this, stated with the estimate: 50%); middle value at least 2.4-fold (0.38 log units) from the limit.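

Moving from 3,5-dichloro-2-hydroxyphenyl to 5-bromothiophen-2-yl on a sulfonyl sulfur replaces the six-membered aromatic ring of carbon only with a five-membered aromatic ring with 1 hetero atom and removes the hydrogen-bond donor, yet in this assay compound 4 is again only a limit, not a number: the limit of > 48200 nM in this assay, at which 1 of the 4 values shown sits. The one readable new step is an at least 2.7-fold higher number from compound 1 to compound 4 (0.44 log units; beyond the scatter), which runs the same way as an at least 2.1-fold higher number from compound 1 to compound 3 (0.34 log units; beyond the scatter), so compound 1 remains the only compound shown with a number. The steps from compound 2 and compound 3 to compound 4 cannot be read.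

Going by these compounds, whether an amine or a carboxylic acid on the aromatic ring, or a plain alkyl chain on the sulfonyl sulfur, would give a number in this assay stays open. Also open, on these data alone, is how the shared core behaves without the sulfonyl group, since all four compounds carry it.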